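Replacing a Methoxyphenyl Group with a Fluorophenyl Group

The compounds below may be only part of what the source reports. "The series", "measured", "known", "first", "only" and "open" are said of these compounds alone.

Of the compounds shown here, three sharing one core have been measured in an assay on membranes from Cerebral cortex for binding affinity to Adrenergic receptor alpha-1 (Rattus norvegicus), read by radioligand binding; on this read-out lower numbers stand for stronger inhibition and higher numbers for weaker inhibition. Compound 1 `O=C1CC(=C(c2ccccc2)c2ccccc2)C(=O)N1CN1CCN(c2cccc(Cl)c2)CC1` gives 392 nM. Compound 2 `O=C1CC(=C(c2ccccc2)c2ccccc2)C(=O)N1CCN1CCN(c2ccccc2)CC1` gives 214 nM. Compound 3 `COc1ccccc1N1CCN(CCN2C(=O)CC(=C(c3ccccc3)c3ccccc3)C2=O)CC1` gives 71.5 nM, the lowest of the three numbers; compound 2 lies nearest and compound 1 furthest, both beyond the scatter. Among the measured compounds shown here, the only single-point step in this set runs from compound 2 to compound 3, where a methoxy replaces a hydrogen on an aromatic carbon and yields a 3.0-fold lower number from compound 2 to compound 3 (0.48 log units; beyond the scatter).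

Compound 4 `O=C1CC(=C(c2ccccc2)c2ccccc2)C(=O)N1CCN1CCN(c2ccc(F)cc2)CC1` has not yet been measured. It differs from compound 3 in one place: 4-fluorophenyl in place of 2-methoxyphenyl on an amine nitrogen in a ring. Compound 4 therefore lacks the methoxy group that compound 3 carries, while compound 2, which also lacks it, gave 214 nM. For the measured compounds named here, the fluorine on the ring has no measured counterpart here, so its contribution is unknown; the only comparison is compound 1, which carries a chlorine but also a shorter link to the core. A modest rise back toward the number of compound 2 is expected. The expected step is a 2.7-fold higher number from compound 3 to compound 4 (0.42 log units; beyond the scatter). Compound 4 is thus estimated at 190 nM, within a range from 75 nM to 480 nM.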

Compound 4, inhibition constant: 529 nM
Estimate against measurement, compound 4: 2.8-fold (0.44 log units) below, and the stated range ends below it.
By their numbers in this assay, from the lowest: compound 3; then compounds 2, 1 and 4 (each within the scatter of the next, the first and the last beyond it).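

The new result shows that, in this assay, a substituent on this phenyl ring can also work against binding: fluoro in place of hydrogen gives a 2.5-fold higher number from compound 2 to compound 4 (0.39 log units; beyond the scatter), the opposite direction to the step produced by methoxy, a 3.0-fold lower number from compound 2 to compound 3 (0.48 log units; beyond the scatter). Exchanging 2-methoxyphenyl for 4-fluorophenyl therefore does more than remove what the methoxy group gained, giving a 7.4-fold higher number from compound 3 to compound 4 (0.87 log units; beyond the scatter), so the unsubstituted phenyl of compound 2 sits between the two substituted rings rather than marking a floor. No measurement here explains why the two substituents pull in opposite directions.

The numbers in the two group names differ, so this exchange changes both the kind of substituent and its place on the ring, and the compounds shown cannot separate those two changes. As far as these compounds go, it also remains open how other groups on this phenyl ring, such as a hydroxy, an ethoxy or a nitrile, would compare, and whether the same pattern would hold with a longer chain joining the piperazine-bearing part to the shared core.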